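Methoxy, methyl and nitro on the fused ring of the core

The source may hold more compounds than are shown below. What is called first, only, known or untested is meant among the compounds shown, and "the series" means these compounds.

Compound 1 `COc1cccc2c1OCN(c1ccc3oc(-c4ccccc4)cc(=O)c3c1)C2` gives 91.9% in a functional assay on MCF7 cells (Homo sapiens) for inhibition, read by MTT assay, with a stated time of 48 h, tested at 60 ug/mL; on this read-out lower numbers stand for less inhibition of growth and higher numbers for more inhibition of growth at the one concentration tested. Compound 2 `Cc1cccc2c1OCN(c1ccc3oc(-c4ccccc4)cc(=O)c3c1)C2` gives 85.1% in this assay; the step of a number 6.8 percentage points lower from compound 1 to compound 2 (within the scatter) is within the scatter, so compound 2 lies alongside compound 1 rather than apart from it. Compound 3 `O=c1cc(-c2ccccc2)oc2ccc(N3COc4c(cccc4[N+](=O)[O-])C3)cc12` carries the change nitro in place of methyl on an aromatic carbon at the same site. Among the measured compounds shown here, only the step from compound 1 to compound 2 bears on this position, and it was within the scatter; no measured pair shows a nitro group. No step beyond the scatter is therefore expected, a number 1.1 percentage points lower from compound 2 to compound 3 (within the scatter), with compound 3 expected at 84%, range 68% to 95%.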

Compound 3, percent growth inhibition at one concentration: 72.9%
The estimate for compound 3 lay 11.1 percentage points above the measured number; measured number inside the range.
By their numbers in this assay, from the lowest: compound 3; then compounds 2 and 1 (each within the scatter of the next).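

Among the compounds shown here, at this site on the aromatic carbon, nitro gives the first change that goes beyond the scatter in this assay, with a number 12.2 percentage points lower from compound 2 to compound 3 (beyond the scatter) and a number 19 percentage points lower from compound 1 to compound 3 (beyond the scatter). The site therefore does respond to the group it carries, though both steps are modest and methoxy and methyl remain within the scatter of each other. Nothing available on these compounds explains the difference. As far as these compounds go, it remains open whether an amine or a carboxylic acid here would stay with methoxy and methyl or fall with nitro. From the compounds shown here alone, whether the nitro step holds across a range of concentrations is also open.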